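Swapping the Sulfonyl Aryl Group: Expected Clearance of Compound 4

This account rests on a few compounds, and the source may have more. Where it says the series, first, only, none or still open, it means among the compounds named here.

Three compounds have been measured in an ADME assay on microsomes from liver (Homo sapiens) for metabolic stability, tested at 2.5 uM; on this read-out higher numbers stand for fast clearance and lower numbers for slow clearance:
compound 1 `COc1cccc(-c2c(S(=O)(=O)c3ccc(OC)c(Cl)c3)cnc3cc(F)ccc23)c1` gives 1.71 mL/min
compound 2 `COc1ccc(-c2c(S(=O)(=O)c3ccc(F)c(Cl)c3)cnc3cc(F)ccc23)cc1` gives 1.08 mL/min
compound 3 `O=S(=O)(c1ccc(F)cc1)c1cnc2cc(F)ccc2c1-c1ccc(Cl)cc1` gives 1.23 mL/min

Compound 1 carries the top number of the three, yet its gap to compound 3 and its gap to compound 2 both fall within the usual scatter of this assay, so on these numbers the three compounds cannot be told apart. The step under study leads from compound 1 to compound 4 `COc1cccc(-c2c(S(=O)(=O)c3cccc(C#N)c3)cnc3cc(F)ccc23)c1`, which has not yet been measured in this assay. The change is 3-cyanophenyl in place of 3-chloro-4-methoxyphenyl on a sulfonyl sulfur. Within the data shown here, no measured pair shows a change of this kind, so nothing here says how large the step will be. The measured compounds differ in the groups carried on the sulfonyl sulfur and on the shared core and still land close together, so a small step is expected, leaning a little toward slower clearance. Compound 4 is estimated at 1.3 mL/min, within 0.7 mL/min to 2.4 mL/min. The expected step of a 1.3-fold lower number from compound 1 to compound 4 (0.12 log units; within the scatter) is estimated to stay within the scatter.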

Compound 4, intrinsic clearance in a liver preparation (reported as CLH), per the amount of preparation that the assay uses: 1.83 mL/min
For compound 4 the middle estimate is 1.4-fold (0.15 log units) below the measured one; the range from low to high includes it.
By their numbers in this assay, from the lowest: compounds 2, 3, 1 and 4 (each within the scatter of the next).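

In this assay, placing 3-cyanophenyl instead of 3-chloro-4-methoxyphenyl on the sulfonyl sulfur gives a 1.1-fold higher number from compound 1 to compound 4 (0.03 log units; within the scatter) and so leaves the clearance reading indistinguishable. This is the only pair shown that differs in one place, so it is the first direct look at this position: with the rest of compound 1 held fixed, these two aryl groups cannot be told apart on this read-out. Nothing available here explains why the two groups read alike.

Still open, on these data alone, is whether the sulfonyl sulfur tolerates very different groups as well, such as a ring carrying an amine or a carboxylic acid, or a longer alkyl chain in place of the ring. This single pair also cannot say whether the same swap would behave alike in compounds with other groups on the shared core.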